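The compounds below may be only part of what the source reports. "The series", "measured", "known", "first", "only" and "open" are said of these compounds alone.

Working notes on the series. In a functional assay on HepG2 cells (Homo sapiens) for cytotoxicity, read by colorimetric assay and neutral red uptake, with a stated time of 72 h (a lower number here means a stronger inhibitor, a higher number a weaker inhibitor), compound 1 (`CO[C@@H](C(=O)N[C@H]1CCCCNC1=O)[C@H](O)[C@@H](O)[C@H](O)/C=C/C(C)(C)C`) gives 21100 nM and compound 2 (`CO[C@@H](C(=O)N[C@H]1CC[C@H](O)CNC1=O)[C@H](O)[C@@H](O)[C@H](O)/C=C/C(C)(C)C`) gives 103000 nM, so compound 2 holds the higher of the two numbers and is the weaker inhibitor of the pair. Among the compounds with values here, the only measured step, a 4.9-fold higher number from compound 1 to compound 2 (0.69 log units; beyond the scatter), is modest and replaces hydrogen with hydroxy on a saturated ring carbon.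

Compound 3 (`CO[C@@H](C(=O)N[C@@H]1CC[C@@H](O)CNC1=O)[C@H](O)[C@@H](O)[C@H](O)/C=C/C(C)(C)C`) is the next to be read. Its relation to the previous compound is: the two compounds have the same atoms and bonds and differ only in configuration as drawn: 2 of 7 stereo elements differ; a stereocentre at a saturated ring carbon is drawn S in compound 2 and R in compound 3; a stereocentre at a saturated ring carbon is drawn S in compound 2 and R in compound 3.

The measured step bears on this change only indirectly, as no stereocentre changes in it. It shows that this assay responds to a change on the ring, and it offers a rough scale, but it gives no direction for a change of configuration. Within the data shown here, with only two measured compounds, the working expectation is a shift of no more than about that modest size, leaning tentatively towards a higher number. The expected step is a 1.7-fold higher number from compound 2 to compound 3 (0.24 log units; within the scatter). The estimated value for compound 3 is 180000 nM, within an expected range of 50000 nM to 600000 nM.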

Compound 3, half-maximal inhibitory concentration: 21300 nM
The estimate for compound 3 lay 8.5-fold (0.93 log units) above the measured number; the measured number lies below the stated range.
By their numbers in this assay, from the lowest: compounds 1 and 3 (each within the scatter of the next); then compound 2.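

In this assay the series now shows a 4.8-fold lower number from compound 2 to compound 3 (0.68 log units; beyond the scatter), with atoms and bonds unchanged, so configuration as drawn alone is enough to move the read-out on this ring. Within the data shown here, the hydroxy group therefore does not carry a higher number with it in every form, as the single earlier step might have suggested. With 6-hydroxy-2-oxoazepan-3-yl in place of 2-oxoazepan-3-yl, the comparison gives a 1.0-fold higher number from compound 1 to compound 3 (0.00 log units; within the scatter), and the gap between the two hydroxy compounds can be assigned to one source only: the fact that compounds 2 and 3 differ only in the configuration as drawn.

Two stereocentres differ together between compound 2 and compound 3, so the compounds shown do not tell whether one of them accounts for the step or both contribute, and the forms in which only one of the two is inverted remain open. Also open, as far as these compounds go, is whether an amine or a fluorine on the same ring carbon would show a similar dependence on configuration, or whether this pattern belongs to the hydroxy group alone.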